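A few compounds are considered here, and "the series" means these few. Any claim that something is new, unique, unknown or untested is made for them only; others in the source may bear on it.

Working notes on the series. Compound 1 `CC(C)C[C@H](N)c1cc(C(F)(F)F)ccc1N1CCN(C(=O)[C@H](C)Cc2ccc(Cl)cc2)CC1` gives 31 nM in an assay on HEK293 cells for displacement of a labelled ligand from Melanocortin receptor 4 (Homo sapiens); a higher number here means a weaker inhibitor, a lower number a stronger inhibitor. Compound 2 `Cc1ccc(OCC(=O)N2CCN(c3ccc(C(F)(F)F)cc3[C@@H](N)CC(C)C)CC2)cc1` gives 4400 nM in this assay, and compound 3 `COc1ccc(CC(C)C(=O)N2CCN(c3ccc(C(F)(F)F)cc3[C@@H](N)CC(C)C)CC2)cc1F` gives 200 nM. Compound 3 thus stands second highest of the three numbers: it is a 6.5-fold higher number from compound 1 to compound 3 (0.81 log units; beyond the scatter) and a 22-fold lower number from compound 2 to compound 3 (1.34 log units; beyond the scatter). The next compound, compound 4 `CC(C)C[C@H](N)c1cc(C(F)(F)F)ccc1N1CCN(C(=O)CCC(=O)c2ccc(Cl)cc2)CC1`, differs from compound 3 by 2-((4-chlorophenyl)carbonyl)ethyl in place of 1-(3-fluoro-4-methoxybenzyl)ethyl on a carbonyl carbon. Among the compounds with values here, the measured steps at this carbonyl carbon were a 140-fold higher number from compound 1 to compound 2 (2.15 log units; beyond the scatter) and a 6.5-fold higher number from compound 1 to compound 3 (0.81 log units; beyond the scatter), so replacements here have ranged from modest to large, with the 4-chlorophenyl ring appearing in the strongest compound, compound 1, and no measured step covers a 2-((4-chlorophenyl)carbonyl)ethyl chain. For compound 4 the expectation is therefore a step of uncertain direction, estimated as a 1.5-fold higher number from compound 3 to compound 4 (0.18 log units; within the scatter), and an inhibition constant of about 300 nM in this assay, within a range from 60 nM to 1500 nM.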

Compound 4, inhibition constant: 820 nM
Estimate against measurement, compound 4: 2.7-fold (0.44 log units) below; the range from low to high includes it.
By their numbers in this assay, from the lowest: compound 1; then compound 3; then compound 4; then compound 2.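

The 4-chlorophenyl ring is kept in the 2-((4-chlorophenyl)carbonyl)ethyl chain, yet a 26-fold higher number from compound 1 to compound 4 (1.42 log units; beyond the scatter) in this assay shows that this ring alone does not retain the low number at this carbonyl carbon. The chain lies between the earlier replacements: a 4.1-fold higher number from compound 3 to compound 4 (0.61 log units; beyond the scatter) and a 5.4-fold lower number from compound 2 to compound 4 (0.73 log units; beyond the scatter) place it in the upper part of the series without reaching the highest number. No evidence on hand bears on these steps.

The compounds shown leave open whether the chain carbonyl or the chain length governs this result. A hydroxyl in place of that carbonyl, or a longer chain bearing the same 4-chlorophenyl ring, would separate the two.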